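This account rests on a few compounds, and the source may have more. Where it says the series, first, only, none or still open, it means among the compounds named here.

Measured so far in an ADME assay on HEK293 cells (Homo sapiens) for cytotoxicity, read by MTT assay, with a stated time of 48 h; a lower number here means a stronger inhibitor, a higher number a weaker inhibitor:

Compound 1 `CCn1c(N)c(-c2nc3ccccc3[nH]2)c2nc(C#N)c(C#N)nc21`: > 50000 nM (a limit of the assay, not a number)
Compound 2 `CN(C)CCn1c(N)c(-c2nc3ccccc3[nH]2)c2nc(C#N)c(C#N)nc21`: 9730 nM
Compound 3 `CN1CCN(CCn2c(N)c(-c3nc4ccccc4[nH]3)c3nc(C#N)c(C#N)nc32)CC1`: 10900 nM

Compound 3, at 10900 nM, stands level with compound 2, at 9730 nM, since a 1.1-fold higher number from compound 2 to compound 3 (0.05 log units; within the scatter). Compound 1 reads > 50000 nM, which is a limit and not a number.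

The next compound is compound 4 `CCCn1c(N)c(-c2nc3ccccc3[nH]2)c2nc(C#N)c(C#N)nc21`. It carries methyl in place of 4-methylpiperazin-1-yl on a saturated chain carbon, two bonds along the chain from an aromatic nitrogen, so the chain end changes to give propyl: methyl in place of 4-methylpiperazin-1-yl on a saturated chain carbon, two bonds along the chain from an aromatic nitrogen.

Among the compounds with values here, two measured steps bear on this change: an at least 4.5-fold lower number from compound 1 to compound 3 (0.66 log units; beyond the scatter), and an at least 5.1-fold lower number from compound 1 to compound 2 (0.71 log units; beyond the scatter). Each places a larger group on the chain of compound 1, and in each the number in this assay falls beyond the scatter. Compound 4 gives up such a group, so the change is read as roughly those steps run backwards, towards a higher number. Within the data shown here, no measured step shows what the extra methyl does on its own.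

The expected size is a 4.1-fold higher number from compound 3 to compound 4 (0.62 log units; beyond the scatter). For compound 4 the estimated value is 45000 nM, with an expected range of 20000 nM to 100000 nM. A report of only a limit is also quite possible.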

Compound 4, half-maximal inhibitory concentration: > 50000 nM
Compound 4: no number, only a limit; the forecaster's own chance of this, stated with the estimate: 60%; middle value at least 1.1-fold (0.04 log units) from the limit.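

In this assay, replacing the amine-bearing chain ends with a plain propyl chain gives an at least 4.5-fold higher number from compound 3 to compound 4 (0.66 log units; beyond the scatter) and an at least 5.1-fold higher number from compound 2 to compound 4 (0.71 log units; beyond the scatter), so the fall in the number seen with dimethylamino and 4-methylpiperazin-1-yl does not come with a chain of similar length that lacks those groups. Compound 4 reads > 50000 nM, which is a limit of the assay and not a number. Among these four compounds, measured numbers appear only for the two whose chains end in an amine, while compound 1 and compound 4 share one limit, so the step between them cannot be read and the effect of the extra methyl on its own stays hidden: the limit of > 50000 nM in this assay, at which 2 of the 4 values shown sit.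

On these data alone, it remains open whether a smaller amine at the chain end, such as a primary amine, would also bring the number down, or whether a morpholin-4-yl or hydroxyl group would do so. As far as these compounds go, it is also open how far the amine can sit from the core, which a longer chain such as butyl carrying dimethylamino at its end would test.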